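Chain extension on an isoquinoline carboxamide of threonine

The source may hold more compounds than are shown below. What is called first, only, known or untested is meant among the compounds shown, and "the series" means these compounds.

The measured compounds are compound 1 `CCCCCCCCCCCCNC(=O)[C@@H](NC(=O)c1nccc2ccccc12)[C@@H](C)O`, compound 2 `CCCCCCCCCCCCNC(=O)[C@@H](NC(=O)c1cc2ccccc2[nH]1)[C@@H](C)O` and compound 3 `CCCCCCCCCCCCNC(=O)[C@@H](NC(=O)c1cc2ccccc2n1C)[C@@H](C)O`. In a functional assay on SW-620 cells (Homo sapiens) for cytotoxicity, read by MTT assay, with a stated time of 48 h (on this read-out higher numbers stand for weaker inhibition and lower numbers for stronger inhibition), compound 1 gives 65800 nM. In this assay compound 2 gives 18800 nM. For compound 3 this assay reports only a limit, > 200000 nM, at the edge of the assay described by the limit of > 200000 nM in this assay, at which 1 of the 3 values shown sits.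

Compound 1 thus stands at the highest of the two plain numbers; its nearest neighbour is compound 2, reached by a 3.5-fold lower number from compound 1 to compound 2 (0.54 log units; beyond the scatter). The other steps, an at least 3.0-fold higher number from compound 1 to compound 3 (0.48 log units; beyond the scatter) and an at least 10-fold higher number from compound 2 to compound 3 (1.02 log units; beyond the scatter), both run into the limit of compound 3.

Compound 4 `CCCCCCCCCCCCCCCCCCNC(=O)[C@@H](NC(=O)c1nccc2ccccc12)[C@@H](C)O` differs from compound 1 by hexyl in place of hydrogen on a saturated chain carbon, ten or more bonds along the chain from an amide-type nitrogen. Among the compounds with values here, none of the measured steps touches the chain; each of them alters the aromatic part attached to the carbonyl, with the chain kept the same throughout. Within the data shown here, there is therefore no measured step that bears on this change, and the expectation for compound 4 in this assay rests on compound 1 alone, a step of no change at the digits printed from compound 1 to compound 4 (within the scatter) expected to stay within the scatter. Compound 4 is estimated at 65800 nM, with a range from 20000 nM to 200000 nM.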

Compound 4, half-maximal inhibitory concentration: 136000 nM
Compound 4: middle estimate off by 2.1-fold (0.32 log units), on the low side, within the range that was stated.
By their numbers in this assay, from the lowest: compound 2; then compound 1; then compound 4. At a limit, above all of these: compound 3.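

Within the data shown here, the chain, identical in compound 1, compound 2 and compound 3, changes here for the first time: hexyl in place of hydrogen on a saturated chain carbon, ten or more bonds along the chain from an amide-type nitrogen, gives a 2.1-fold higher number from compound 1 to compound 4 (0.32 log units; beyond the scatter) in this assay. This place on the chain is therefore not silent on this read-out, and with the core of compound 1 the added carbons go with modestly weaker inhibition. Nothing shown here gives a cause for this step.

From the compounds shown here alone, a single lengthening on one core shows no trend with chain length, and whether hexyl would act alike on the core of compound 2 stays open. The compounds shown also leave open how a shorter chain, or an amine or a carboxylic acid in place of hexyl, would read.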